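The compounds below may be only part of what the source reports. "The series", "measured", "known", "first", "only" and "open" are said of these compounds alone.

Compound 1 has the structure `CCCCCc1ccc(C#Cc2c(-c3ccc(C)cc3)oc3nc(=O)n([C@H]4C[C@H](OC(C)=O)[C@@H](COC(C)=O)O4)cc23)cc1`. In an ADME assay on HEL cells (Homo sapiens) for cytotoxicity, read by cell counting, with a stated time of 3 days (a lower number here means that less compound is tolerated, a higher number that more compound is tolerated), compound 1 gives "not determined" (no result reported), so no number places it on the scale at all. Compound 2, with the structure `CC(=O)OC[C@H]1O[C@@H](n2cc3c(C#CCCN4C(=O)c5ccccc5C4=O)c(-c4ccc(C)cc4)oc3nc2=O)C[C@@H]1OC(C)=O`, stands in the same position: in this assay compound 2 gives "not determined" (no result reported). Only compound 3, with the structure `CCCCCc1ccc(C#Cc2c(-c3ccc(CCCCC)cc3)oc3nc(=O)n([C@H]4C[C@H](OC(C)=O)[C@@H](COC(C)=O)O4)cc23)cc1`, carries a reading, and that reading is a limit of the assay rather than a number: in this assay compound 3 gives > 100000 nM. Among the measured compounds shown here, this is the limit of > 100000 nM in this assay, at which 1 of the 3 values shown sits, and it is the whole of what the series shows in this assay so far. For the measured compounds named here, no step between measured compounds can be drawn from it.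

Compound 4 has the structure `CC(=O)OC[C@H]1O[C@@H](n2cc3c(C#Cc4ccc(C)cc4)c(-c4ccc(C)cc4)oc3nc2=O)C[C@@H]1OC(C)=O`. It differs from compound 1 by hydrogen in place of butyl on a saturated chain carbon bound to an aromatic carbon. Going by the values given here, no measured step exists between compounds that differ in one place, so the size and direction of the change from compound 1 to compound 4 in this assay cannot be read from the data, and no step beyond the scatter can be claimed in either direction. Among the compounds with values here, the one reading in hand, that of compound 3, is a limit. Compound 4 is therefore expected to sit near that same limit, at an estimated 100000 nM, within a range from 30000 nM to 300000 nM, with a fair chance that the assay again reports only a limit.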

Compound 4, half-maximal cytotoxic concentration: 8770 nM
Compound 4: middle estimate off by 11-fold (1.06 log units), on the high side, and the stated range ends above it.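

No step can be read between compound 1 and compound 4: in this assay compound 1 gives "not determined" (no result reported), so the reading of compound 4 has no partner to be set against. The compounds shown leave open how the change from 4-pentylphenyl to 4-methylphenyl shifts the reading in this assay.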